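A few compounds are considered here, and "the series" means these few. Any claim that something is new, unique, unknown or untested is made for them only; others in the source may bear on it.

Measured compounds:
compound 1, `O=C1/C(=C/c2ccccc2F)CN(S(=O)(=O)c2ccc(O[N+](=O)[O-])cc2)C/C1=C\c1ccccc1F`, 15500 nM
compound 2, `N#Cc1ccc(S(=O)(=O)N2C/C(=C\c3ccccc3F)C(=O)/C(=C/c3ccccc3F)C2)cc1`, 11000 nM
compound 3, `Cc1ccc(S(=O)(=O)N2C/C(=C\c3cccc(F)c3)C(=O)/C(=C/c3cccc(F)c3)C2)cc1`, 15700 nM

In an ADME assay on L02 cells (Homo sapiens) for cytotoxicity, read by MTT assay, with a stated time of 24 h (a higher number here means a weaker inhibitor, a lower number a stronger inhibitor), compound 3 gives 15700 nM, the highest of the three numbers shown, although compound 1 gives 15500 nM and compound 2 gives 11000 nM, and both of these lie within the scatter of the value for compound 3. The step to compound 4, `N#Cc1ccc(S(=O)(=O)N2C/C(=C\c3cccc(F)c3)C(=O)/C(=C/c3cccc(F)c3)C2)cc1`, is cyano in place of methyl on an aromatic carbon. Among the compounds with values here, no measured pair shows exactly this exchange of methyl for cyano. The nearest comparison is a 1.4-fold lower number from compound 1 to compound 2 (0.15 log units; within the scatter), where a cyano group likewise entered on an aromatic carbon in place of another group on the ring carrying the sulfonyl, and the number did not move beyond the scatter. Within the data shown here, that single comparison is the only guide available here, and it bears on the present step only by the shared entering group. On that basis the step from compound 3 to compound 4 is expected to stay within the scatter in this assay as well, with at most a slight drift toward a lower number, as a 1.3-fold lower number from compound 3 to compound 4 (0.12 log units; within the scatter). Compound 4 is therefore estimated at 12000 nM, with a range from 6000 nM to 25000 nM.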

Compound 4, half-maximal inhibitory concentration: 15500 nM
Compound 4: middle estimate off by 1.3-fold (0.11 log units), on the low side, within the range that was stated.
By their numbers in this assay, from the lowest: compounds 2, 1, 4 and 3 (each within the scatter of the next).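

In this assay the exchange of methyl for cyano, on an aromatic carbon para to a large group, gives a 1.0-fold lower number from compound 3 to compound 4 (0.01 log units; within the scatter) and so stays within the scatter. Within the data shown here, this is the first direct reading of cyano against methyl at this place: the earlier pair, with a 1.4-fold lower number from compound 1 to compound 2 (0.15 log units; within the scatter) as its step, set cyano against nitrooxy on a different fluorine pattern, and it too stayed within the scatter. The 4-methylphenyl and 4-cyanophenyl forms of the sulfonyl group are thus not told apart by this read-out on the core of compound 3, and no measurement shown accounts for this result.

The compounds shown leave open whether a group of another kind at this place, such as an amine, a carboxylic acid or a longer alkyl chain, would also stay within the scatter, since only methyl, cyano and nitrooxy appear there. They also leave open whether the exchange of methyl for cyano would read the same on the core of compound 1, where only the exchange of nitrooxy for cyano can be read.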